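Changing the fused ring pair on the side chain

A few compounds are considered here, and "the series" means these few. Any claim that something is new, unique, unknown or untested is made for them only; others in the source may bear on it.

Compound 3 `O=C1O/C(=C\Cn2cnc3ccnc(Cl)c32)C(OCc2ccccc2)=C1OCc1ccccc1` stands in a functional assay on L1210/0 cells (Mus musculus) for antiproliferative activity, read by MTT assay, with a stated time of 72 h (on this read-out lower numbers stand for stronger inhibition and higher numbers for weaker inhibition), as "not determined" (no result reported), so its standing can be read only from the compounds around it. Compound 1 `O=C1O/C(=C\Cn2cnc3cc[nH]c3c2=O)C(OCc2ccccc2)=C1OCc1ccccc1` gives 28000 nM in this assay, and compound 2 `O=C1O/C(=C\Cn2cnc3cncc(Br)c32)C(OCc2ccccc2)=C1OCc1ccccc1` gives 6800 nM. Within the data shown here, the single measured step, a 4.1-fold lower number from compound 1 to compound 2 (0.61 log units; beyond the scatter), is the only guide to what exchanging the fused ring pair on the side chain does. Compound 4 `O=C1O/C(=C\Cn2cnc3ncc(Br)c-3c2)C(OCc2ccccc2)=C1OCc1ccccc1` differs from compound 3 by a group of 10 heavy atoms (6 carbon, 3 nitrogen, 1 bromine; one five-membered aromatic ring with 1 hetero atom, one six-membered aromatic ring with 2 hetero atoms) in place of a group of 10 heavy atoms (6 carbon, 3 nitrogen, 1 chlorine; one five-membered aromatic ring with 2 hetero atoms, one six-membered aromatic ring with 1 hetero atom), on a saturated chain carbon bound to a double-bonded chain carbon. Among the measured compounds shown here, with no value for compound 3, no step from compound 3 to compound 4 can be stated, and the expectation rests on the step between compound 1 and compound 2, which moved by a 4.1-fold lower number from compound 1 to compound 2 (0.61 log units; beyond the scatter). Compound 2 carries a bromine in its fused rings and gave 6800 nM; compound 4 also carries a bromine in its fused rings, and the estimate leans on that value, with wide uncertainty. Compound 4 is expected to give about 9000 nM, with a range from 2500 nM to 35000 nM.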

Compound 4, half-maximal inhibitory concentration: 15000 nM
Estimate against measurement, compound 4: 1.7-fold (0.22 log units) below; the measured number falls inside the stated range.
By their numbers in this assay, from the lowest: compound 2; then compounds 4 and 1 (each within the scatter of the next).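

The bromine-bearing groups of compound 2 and compound 4 hold the same heavy atoms and differ only in how the hetero atoms are shared between the five-membered and six-membered aromatic rings. In this assay, that rearrangement alone gives a change beyond the scatter, a 2.2-fold higher number from compound 2 to compound 4 (0.34 log units; beyond the scatter). The other new step, a 1.9-fold lower number from compound 1 to compound 4 (0.27 log units; within the scatter), shows that a bromine in the fused rings does not by itself set a compound apart from the bromine-free group with its ring oxygen.

Among these compounds, compound 3, the only chlorine compound, has no result, and whether an amine or a methyl group in place of the bromine would keep this level of activity stays open. Nothing available explains why the two ring arrangements give different numbers.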